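Swapping Sulfur for Selenium on a Shared Core

This account rests on a few compounds, and the source may have more. Where it says the series, first, only, none or still open, it means among the compounds named here.

Compound 1 `COc1ccc(CNc2nc(SC)nc3ccccc23)cc1` is one of three closely related compounds tested in a functional assay on HT-29 cells (Homo sapiens) for cytotoxicity, read by MTT assay, with a stated time of 72 h; on this read-out lower numbers stand for higher toxicity in this test and higher numbers for lower toxicity in this test. In this assay compound 1 gives > 100000 nM, which is a limit of the assay rather than a number. Compound 2 `CSc1nc(NCc2ccccc2)c2ccccc2n1` gives > 100000 nM, also a limit. Compound 3 `CSc1ccc(CNc2nc(SC)nc3ccccc23)cc1` gives > 100000 nM, again a limit. Because all three sit at the limit of > 100000 nM in this assay, at which 3 of the 3 values shown sit, the steps a step that the two limits leave unreadable from compound 1 to compound 2, a step that the two limits leave unreadable from compound 1 to compound 3 and a step that the two limits leave unreadable from compound 2 to compound 3 cannot be sized. Compound 4 `COc1ccc(CNc2nc([Se]C)nc3ccccc23)cc1` differs from compound 1 by a group of 2 heavy atoms (1 carbon, 1 selenium; no ring) in place of a group of 2 heavy atoms (1 carbon, 1 sulfur; no ring), on an aromatic carbon. Among the compounds with values here, no measured step covers this change, so no direction can be read from the numbers. Compound 4 is therefore expected to give roughly 60000 nM in this assay, between 10000 nM and 200000 nM, an estimated step of an at least 1.6-fold lower number from compound 1 to compound 4 (0.22 log units; that floor lies within the scatter) that may again be reported only as a limit.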

Compound 4, concentration lethal to 50% of the cells: > 100000 nM
Compound 4: a limit, no number (the forecaster's own chance of this, stated with the estimate: 55%); middle value at least 1.6-fold (0.22 log units) from the limit.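

Compound 4, like compound 1, gives only a limit rather than a number, so no step between them can be read: the limit of > 100000 nM in this assay, at which 4 of the 4 values shown sit.

On these data alone, whether selenium in place of sulfur changes the result in this assay stays open.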